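Urea aryl swap in thienopyrimidine series: transfer to diethylamino analogue

The source may report more compounds than this note shows. Statements on the series, on what has been measured and on what is new or still open speak of the compounds shown alone.

Compound 1 `CN(C)CCNc1nc(-c2ccc(NC(=O)Nc3ccccc3Cl)cc2)nc2ccsc12` gives 310 nM in a functional assay on HT-29 cells (Homo sapiens) for cytotoxicity, read by MTT assay, with a stated time of 72 h; a lower number here means a stronger inhibitor, a higher number a weaker inhibitor. Compound 2 `Cc1ccc(NC(=O)Nc2ccc(-c3nc(NCCN(C)C)c4sccc4n3)cc2)cc1` gives 2150 nM in this assay. The change between them is 4-methylphenyl in place of 2-chlorophenyl on an amide-type nitrogen and the step is a 6.9-fold higher number from compound 1 to compound 2 (0.84 log units; beyond the scatter). Compound 3 `CCN(CC)CCCNc1nc(-c2ccc(NC(=O)Nc3ccccc3Cl)cc2)nc2ccsc12` gives 340 nM in this assay; its core differs from that of compound 1 by (diethylamino)methyl in place of dimethylamino on a saturated chain carbon, two bonds along the chain from a nitrogen on an aromatic ring, with the step of a 1.1-fold higher number from compound 1 to compound 3 (0.04 log units; within the scatter). Compound 4 `CCN(CC)CCCNc1nc(-c2ccc(NC(=O)Nc3ccc(C)cc3)cc2)nc2ccsc12` is not yet measured; it differs from compound 3 by 4-methylphenyl in place of 2-chlorophenyl on an amide-type nitrogen, the same change at the same place as seen between compound 1 and compound 2. The step from compound 3 to compound 4 is expected to be about a 6.8-fold higher number from compound 3 to compound 4 (0.83 log units; beyond the scatter), because the earlier instance of this change gave a 6.9-fold higher number from compound 1 to compound 2 (0.84 log units; beyond the scatter). Compound 4 is therefore estimated at 2300 nM in this assay, expected between 1000 nM and 5500 nM.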

Compound 4, half-maximal inhibitory concentration: 1620 nM
Estimate against measurement, compound 4: 1.4-fold (0.15 log units) above, within the range that was stated.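

In this assay, the change from 2-chlorophenyl to 4-methylphenyl on the core of compound 3 gives a 4.8-fold higher number from compound 3 to compound 4 (0.68 log units; beyond the scatter), and the two instances of this change agree: the same change on two cores in this assay, a 6.9-fold higher number (0.84 log units; beyond the scatter) from compound 1 to compound 2 and a 4.8-fold higher number (0.68 log units; beyond the scatter) from compound 3 to compound 4, 1.5-fold (0.16 log units) apart, within the scatter of two such steps. The side-chain change also reads the same with 4-methylphenyl in place, with a 1.3-fold lower number from compound 2 to compound 4 (0.12 log units; within the scatter): the same change on two cores in this assay, a 1.1-fold higher number (0.04 log units; within the scatter) from compound 1 to compound 3 and a 1.3-fold lower number (0.12 log units; within the scatter) from compound 2 to compound 4, 1.5-fold (0.16 log units) apart, within the scatter of two such steps. This shows that the aryl change carried over between these two cores, but it rests on one pair of aryl groups and two side chains and does not show that it would hold on other cores.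

The compounds shown change the chlorine and the methyl together, leaving the contribution of each open; 4-chlorophenyl or unsubstituted phenyl on the same nitrogen would separate them. Going by these compounds, whether the transfer extends to a side chain ending in a morpholine also remains open.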